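The source may hold more compounds than are shown below. What is called first, only, known or untested is meant among the compounds shown, and "the series" means these compounds.

Measured so far in a functional assay on A-375 cells (Homo sapiens) for antiproliferative activity, read by MTT assay, with a stated time of 24 h, tested at 33.33 ug/mL; on this read-out lower numbers stand for a weaker effect and higher numbers for a stronger effect at the one concentration tested:
- compound 1 `Cc1ccc2nc(C(=O)Nc3c(F)cc(-c4cccc(F)c4)cc3F)c(C)c(C(=O)O)c2c1` gives 26.3%
- compound 2 `CCc1ccc2nc(C(=O)Nc3c(F)cc(-c4cccc(F)c4)cc3F)c(C)c(C(=O)O)c2c1` gives 47.1%
- compound 3 `CCOc1ccc2nc(C(=O)Nc3c(F)cc(-c4cccc(F)c4)cc3F)c(C)c(C(=O)O)c2c1` gives 51.2%

Compound 3 gives the highest of the three numbers, though its gap to compound 2, a number 4.1 percentage points higher from compound 2 to compound 3 (within the scatter), lies within the scatter; only the gap to compound 1, a number 24.9 percentage points higher from compound 1 to compound 3 (beyond the scatter), lies beyond it. Compound 4 `COc1ccc2nc(C(=O)Nc3c(F)cc(-c4cccc(F)c4)cc3F)c(C)c(C(=O)O)c2c1` differs from compound 3 by hydrogen in place of methyl on a saturated chain carbon bound to an oxygen on an aromatic ring. The closest measured parallel is the step of a number 20.8 percentage points higher from compound 1 to compound 2 (beyond the scatter), where adding a methyl on a chain carbon raised the number; compound 4 instead loses such a methyl. A modest fall in this assay is therefore expected, a number 13.2 percentage points lower from compound 3 to compound 4 (beyond the scatter), so compound 4 is estimated at 38%, with a range from 22% to 55%.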

Compound 4, a percentage reported as inhibition, at one concentration (the size of the read-out at that concentration, not a potency): 44.5%
Beside the measured number, compound 4's estimate is 6.5 percentage points below it; measured number inside the range.
By their numbers in this assay, from the lowest: compound 1; then compounds 4, 2 and 3 (each within the scatter of the next).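

In this assay, ethoxy and methoxy at this position cannot be told apart, with a number 6.7 percentage points lower from compound 3 to compound 4 (within the scatter), and neither can methoxy and ethyl, with a number 2.6 percentage points lower from compound 2 to compound 4 (within the scatter). Methoxy does stand clear of the plain methyl, with a number 18.2 percentage points higher from compound 1 to compound 4 (beyond the scatter). The added methyl therefore does not count the same everywhere, as it shifts the number less on the oxygen-linked chain than on the carbon-linked one: the same change on two cores in this assay, a number 20.8 percentage points higher (beyond the scatter) from compound 1 to compound 2 and a number 6.7 percentage points higher (within the scatter) from compound 4 to compound 3, 14.1 percentage points apart, beyond the scatter of two such steps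

Going by these compounds, whether a longer chain such as butoxy, or an amine at this position, would lift the number clear of compound 2, compound 3 and compound 4 stays open.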